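This account rests on a few compounds, and the source may have more. Where it says the series, first, only, none or still open, it means among the compounds named here.

In an in vitro ADME assay on microsomes from liver (Homo sapiens) for metabolic stability, tested at 1 uM (on this read-out higher numbers stand for a longer-lived compound and lower numbers for a shorter-lived compound), compound 1 (`Cc1cc(/C=C/C#N)cc(C)c1Oc1cc(Nc2ccc(C#N)cc2)c(N)cc1C(N)=O`) gives 0.583 h and compound 2 (`COC(=O)c1cc(N)c(Nc2ccc(C#N)cc2)cc1Oc1c(C)cc(CCC#N)cc1C`) gives 3.1 h as the higher of the two numbers, a gap beyond the usual scatter. Compound 3 (`COC(=O)c1cc(N)c(Nc2ccc(C#N)cc2)cc1Oc1c(C)cc(/C=C/C#N)cc1C`) differs from compound 2 in one place, with 2-cyanoethenyl in place of 2-cyanoethyl on an aromatic carbon. Going by the values given here, no measured pair shows this change alone. Compound 1 also carries 2-cyanoethenyl and gives 0.583 h so a shorter half-life is expected, though with wide uncertainty. The expected drop is a 2.2-fold lower number from compound 2 to compound 3 (0.35 log units; beyond the scatter) near the edge of the scatter. Compound 3 is estimated at 1.4 h with an expected range from 0.5 h to 3.5 h.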

Compound 3, half-life in the Homo sapiens assay: 4.72 h
Compound 3: the middle estimate sits 3.4-fold (0.53 log units) below what was measured; measured number above the stated range.
By their numbers in the Homo sapiens assay, from the lowest: compound 1; then compounds 2 and 3 (each within the scatter of the next).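

In the Homo sapiens assay the swap of 2-cyanoethyl for 2-cyanoethenyl at this position stays within the scatter (a 1.5-fold higher number from compound 2 to compound 3 (0.18 log units; within the scatter)), so 2-cyanoethenyl alone does not go with the short half-life of compound 1. The step that clearly separates the numbers lies elsewhere, with methoxy in place of amino on a carbonyl carbon (an 8.1-fold higher number from compound 1 to compound 3 (0.91 log units; beyond the scatter)). In a physicochemical assay for solubility, with a stated time of 4 h, at pH 2.0 (on this read-out higher numbers stand for higher solubility and lower numbers for lower solubility), compound 2 gives 21.8 ug/mL and compound 3 gives 1.75 ug/mL, so the same swap does show there: the measured solubility of compound 2, 21.8 ug/mL, and of compound 3, 1.75 ug/mL, a 12-fold lower number (1.10 log units; beyond the scatter).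

Going by these compounds, whether an amine or a longer chain at this position would keep the half-life and give higher solubility remains open. Also open, on these data alone, is whether the methoxy-for-amino step would be the same size with 2-cyanoethyl present.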